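The compounds below may be only part of what the source reports. "The series", "measured", "known", "first", "only" and "open" are said of these compounds alone.

Of the compounds shown here, two sharing one core have so far been tested in an ADME assay on J774 cells (Mus musculus) for cytotoxicity, read by MTT assay, with a stated time of 48 h; on this read-out higher numbers stand for weaker inhibition and lower numbers for stronger inhibition. Compound 1 `CN(C)CC(=O)NCCNc1cc(/C=C/c2ccccc2)nc2ccccc12` gives 15000 nM in this assay. Compound 2 `O=C(CNc1ccccc1)NCCCCNc1cc(/C=C/c2ccccc2)nc2ccccc12` gives 3300 nM in this assay. Of these two numbers, compound 1 stands highest, and its gap to compound 2 lies beyond the usual scatter, so compound 1 is the weaker of the two at harming these cells.

Compound 3 `O=C(CNc1ccc(Cl)cc1Cl)NCCNc1cc(/C=C/c2ccccc2)nc2ccccc12` has not yet been measured. It differs from compound 1 in one place: (2,4-dichlorophenyl)amino in place of dimethylamino on a saturated chain carbon bound to a carbonyl carbon. Among the measured compounds shown here, no pair of measured compounds shows exactly this change, so any expectation must rest on the two numbers already in hand. In its build, compound 3 lies nearer to compound 2, whose number in this assay, 3300 nM, is the lower one. On that basis the step is expected to run downward, toward stronger inhibition, by about a 3.3-fold lower number from compound 1 to compound 3 (0.52 log units; beyond the scatter). For compound 3 the estimated value in this assay is 4500 nM, with a plausible range from 1500 nM to 13000 nM.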

Compound 3, half-maximal inhibitory concentration: > 50000 nM
Compound 3 ended at the assay's limit; the forecaster's own chance of this, stated with the estimate: 5%; at least 11-fold (1.04 log units) between middle value and limit.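

In this assay compound 3 gives > 50000 nM, which is a limit of the assay and not a number. This is the first change shown at a single place, on a saturated chain carbon bound to a carbonyl carbon, and it links the two structures directly: (2,4-dichlorophenyl)amino in place of dimethylamino brings an at least 3.3-fold higher number from compound 1 to compound 3 (0.52 log units; beyond the scatter), so on this read-out the cells are harmed less once the aromatic ring is present at this position. That step can be read only as a minimum, and its full size stays unknown, because the measurement stops at the edge of the assay's range: the limit of > 50000 nM in this assay, at which 1 of the 3 values shown sits.

The compounds shown leave open whether the step comes from the six-membered aromatic ring itself or from its two chlorine atoms, a question that plain phenylamino on the same chain as compound 1 would help to settle. They also leave open how a cyclic amine such as morpholine or a carboxylic acid would read at this position, so the pattern rests on this one pair alone.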